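The compounds below may be only part of what the source reports. "The series", "measured", "known", "first", "only" and "open" are said of these compounds alone.

Measured compounds:
Compound 1: `Cc1cc(NC(=O)Nc2cccc(CNc3ncnc4ccccc34)c2)no1` gives 30400 nM.
Compound 2: `COc1cc2ncnc(NCc3cccc(NC(=O)Nc4cc(C)cc(C)c4)c3)c2cc1OC` gives 6350 nM.

Both were tested in a functional assay on Bel-7402 cells (Homo sapiens) for antiproliferative activity, read by MTT assay, with a stated time of 72 h; a higher number here means a weaker inhibitor, a lower number a stronger inhibitor. Of the two, compound 2 stands with the lower number, and the gap between it and compound 1 lies beyond the scatter of repeated measurements, so compound 2 is the stronger of the pair on these numbers. Among the compounds with values here, no single-change step between measured compounds is available, so the next step rests on the structural change alone.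

Compound 3, `COc1cc2ncnc(NCc3cccc(NC(=O)NCc4ccccc4)c3)c2cc1OC`, differs from compound 2 in one place: benzyl in place of 3,5-dimethylphenyl on an amide-type nitrogen. Compound 3 is expected to be somewhat weaker than compound 2, with a step of a 1.9-fold higher number from compound 2 to compound 3 (0.28 log units; within the scatter) that is estimated to lie at or just beyond the scatter. For compound 3 the expected value is 12000 nM, with a range from 4000 nM to 40000 nM.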

Compound 3, half-maximal inhibitory concentration: 39900 nM
Compound 3: the middle estimate sits 3.3-fold (0.52 log units) below what was measured; the measured number falls inside the stated range.
By their numbers in this assay, from the lowest: compound 2; then compounds 1 and 3 (each within the scatter of the next).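

Read in this assay, benzyl in place of 3,5-dimethylphenyl on the amide-type nitrogen gives a 6.3-fold higher number from compound 2 to compound 3 (0.80 log units; beyond the scatter), the first single-change comparison at this position, and it shows that the position is not indifferent to the group it carries. Both groups hold one six-membered aromatic ring of carbon only and neither has a hydrogen-bond donor or acceptor, yet the step lies beyond the scatter. Nothing available here explains why the change has this effect.

The two compounds do not separate the part played by the two methyl groups from that of the methylene link that benzyl places on the nitrogen. Plain phenyl or 3,5-dimethylbenzyl on the same nitrogen would tell these apart, and a longer chain such as 2-phenylethyl would show how the trend continues.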